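This account rests on a few compounds, and the source may have more. Where it says the series, first, only, none or still open, it means among the compounds named here.

Compound 3 `CCOc1nc2nc(C)cc(Nc3ccc(C(F)(F)F)cc3)n2n1` carries an ethoxy group on the shared core. In an in vitro ADME assay on microsomes from liver (Mus musculus) for metabolic stability (on this read-out higher numbers stand for fast clearance and lower numbers for slow clearance), compound 3 gives 14.4 mL.min-1.g-1. Compound 1 `COCc1nc2nc(C)cc(Nc3ccc(C(F)(F)F)cc3)n2n1` gives 13.3 mL.min-1.g-1 in this assay, and compound 2 `CCOc1nc2nc(C)cc(Nc3ccc(S(F)(F)(F)(F)F)cc3)n2n1` gives 11.3 mL.min-1.g-1; the steps of a 1.1-fold higher number from compound 1 to compound 3 (0.03 log units; within the scatter) and a 1.3-fold higher number from compound 2 to compound 3 (0.11 log units; within the scatter) both leave compound 3 within the scatter of its neighbours, so no real ordering among the three can be claimed. Compound 4 `COCCc1nc2nc(C)cc(Nc3ccc(C(F)(F)F)cc3)n2n1` differs from compound 3 by 2-methoxyethyl in place of ethoxy on an aromatic carbon. For the measured compounds named here, only the step from compound 1 to compound 3, methoxymethyl giving way to ethoxy at the same place, bears on this exchange, and it was flat. A related change is therefore expected to stay within the scatter, with a 1.0-fold lower number from compound 3 to compound 4 (0.01 log units; within the scatter). Compound 4 is estimated at 14 mL.min-1.g-1, between 8 mL.min-1.g-1 and 25 mL.min-1.g-1.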

Compound 4, intrinsic clearance in microsomes: 14.3 mL.min-1.g-1
The estimate for compound 4 lay 1.0-fold (0.01 log units) below the measured number; low and high end bracket the measured number.
By their numbers in this assay, from the lowest: compounds 2, 1, 4 and 3 (each within the scatter of the next).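

In this assay, a third chain on the five-membered aromatic ring leaves the read-out flat, with a 1.0-fold lower number from compound 3 to compound 4 (0.00 log units; within the scatter) and a 1.1-fold higher number from compound 1 to compound 4 (0.03 log units; within the scatter). Ethoxy, methoxymethyl and 2-methoxyethyl therefore read alike at this position, whether or not the oxygen sits directly on the ring. No measurement here accounts for this sameness. On these data alone, all three groups are small, uncharged oxygen-bearing chains, so this position remains untested with very different groups. An amine, a carboxylic acid or a much longer chain could still shift clearance beyond the scatter.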